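The source may hold more compounds than are shown below. What is called first, only, known or untested is meant among the compounds shown, and "the series" means these compounds.

Compound 1 `Cc1ccc(-c2cnnc(NCc3cc(-c4ccccc4)[nH]n3)n2)cc1` and compound 2 `Cc1ccccc1-c1cncc(NCc2cc(-c3ccccc3)[nH]n2)c1` were both tested in an ADME assay on CEM174 cells (Homo sapiens) for cytotoxicity; a higher number here means that more compound is tolerated, a lower number that less compound is tolerated. In this assay compound 1 gives > 10000 nM, which is a limit of the assay rather than a number. In this assay compound 2 likewise gives > 10000 nM, again only a limit. Both compounds share (the limit of > 10000 nM in this assay, at which 2 of the 2 values shown sit), so compound 2 cannot be set apart from compound 1. Compound 3 `Cc1cc(C#N)ccc1-c1cncc(NCc2cc(-c3ccccc3)[nH]n2)c1` has not yet been measured. It differs from compound 2 by cyano in place of hydrogen on an aromatic carbon. Within the data shown here, no measured step exists to lean on. The step in this assay is expected to be a step that the limit leaves unreadable from compound 2 to compound 3, no larger than the scatter. Compound 3 is therefore expected to give about 15000 nM, within 5000 nM to 50000 nM.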

Compound 3, half-maximal cytotoxic concentration: > 10000 nM
Compound 3: no number, only a limit; the forecaster's own chance of this, stated with the estimate: 80%; the middle value does not contradict the limit.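

No step from compound 2 to compound 3 can be read, because both results in this assay are limits rather than numbers: the limit of > 10000 nM in this assay, at which 3 of the 3 values shown sit.

On these data alone, whether the cyano group changes how much compound is tolerated, and at what concentration compound 1, compound 2 or compound 3 would become toxic to the cells, remains open.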